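What One Inverted Stereocentre May Do to Compound 2

This account rests on a few compounds, and the source may have more. Where it says the series, first, only, none or still open, it means among the compounds named here.

Measured so far in a functional assay on A549 cells (Homo sapiens) for cytotoxicity, read by sulforhodamine B assay; on this read-out higher numbers stand for weaker inhibition of growth and lower numbers for stronger inhibition of growth:

- compound 1 `COC1=C(Br)[C@H](O)[C@@]2(C=C1Br)CC(C(=O)NCCCCCNC(=O)C1=NO[C@]3(C=C(Br)C(=O)[C@@H](Br)[C@@H]3O)C1)=NO2`: 4500 nM
- compound 2 `COC1=C(Br)[C@H](O)[C@@]2(C=C1Br)CC(C(=O)NCCCCNC(=O)C1=NO[C@]3(C=C(Br)C(=O)[C@@H](Br)[C@@H]3O)C1)=NO2`: 5700 nM
- compound 3 `COC1=C(Br)[C@H](O)[C@@]2(C=C1Br)CC(C(=O)NCCCCCNC(=O)C1=NO[C@]3(C=C(Br)C(=O)[C@H](Br)[C@@H]3O)C1)=NO2`: 5400 nM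

Compound 2, at 5700 nM, sits within the usual scatter of repeated measurements of both other compounds, so these three values cannot be ranked.

The next compound to be tested is compound 4 `COC1=C(Br)[C@H](O)[C@@]2(C=C1Br)CC(C(=O)NCCCCNC(=O)C1=NO[C@]3(C=C(Br)C(=O)[C@H](Br)[C@@H]3O)C1)=NO2`. Its relation to compound 2 is the two compounds have the same atoms and bonds and differ only in configuration as drawn: 1 of 5 stereo elements differ; a stereocentre at a saturated ring carbon is drawn S in compound 2 and R in compound 4. The two compounds have the same atoms and bonds, and a stereocentre at a saturated ring carbon is drawn S in compound 2 and R in compound 4. A stereocentre is a carbon whose groups can be arranged in space in two ways, so this change alters the shape but not the composition.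

Among the compounds with values here, one measured step bears on this change: a 1.2-fold higher number from compound 1 to compound 3 (0.08 log units; within the scatter). That comparison isolates configuration, as the fact that compounds 1 and 3 differ only in the configuration as drawn shows. A single pair is thin evidence, but because of a 1.2-fold higher number from compound 1 to compound 3 (0.08 log units; within the scatter) no shift beyond the scatter is expected in this assay, and no direction can be relied on. The expected size of the change is a 1.1-fold higher number from compound 2 to compound 4 (0.02 log units; within the scatter). For compound 4 the estimated value is 6000 nM, with an expected range of 3500 nM to 10000 nM.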

Compound 4, concentration for 50% growth inhibition: 5600 nM
Compound 4: the middle estimate sits 1.1-fold (0.03 log units) above what was measured; low and high end bracket the measured number.
By their numbers in this assay, from the lowest: compounds 1, 3, 4 and 2 (each within the scatter of the next).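

In this assay, the inverted stereocentre at a saturated ring carbon gives a 1.0-fold lower number from compound 2 to compound 4 (0.01 log units; within the scatter), and this step can be set beside a 1.2-fold higher number from compound 1 to compound 3 (0.08 log units; within the scatter). Neither step lies beyond the scatter, so the same inversion has now been examined with two different linking chains, and neither pair shows a change that can be read. Until now a single pair carried this point, whereas compounds 2 and 4 give a second comparison that isolates configuration in the same way: the fact that compounds 2 and 4 differ only in the configuration as drawn.

The compounds shown leave open whether this stereocentre would remain without a readable effect in a compound with a longer chain, or with an amine in place of an amide in the linking chain. They also leave open what inverting any of the other stereocentres would do, and whether the same result would appear in a read-out other than this assay, since every comparison here comes from that single measurement on one cell type.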